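Replacing 3-methoxyphenyl with 1-methyl-1H-indol-5-yl

The source may hold more compounds than are shown below. What is called first, only, known or untested is meant among the compounds shown, and "the series" means these compounds.

Of the compounds shown here, three sharing one core have been measured in a functional assay on MGC-803 cells (Homo sapiens) for inhibition, read by MTT assay, with a stated time of 48 h; a higher number here means a weaker inhibitor, a lower number a stronger inhibitor. Compound 3 (`COc1cccc(Nc2nnc(Cl)c(Nc3cc(OC)c(OC)c(OC)c3)n2)c1`) gives 16500 nM and compound 1 (`COc1cc(Nc2nnc(Cl)c(Nc3cc(OC)c(OC)c(OC)c3)n2)cc(OC)c1OC`) gives 24300 nM (two values within the scatter of each other). Compound 2 (`CCOC(=O)c1ccc(Nc2nnc(Cl)c(Nc3cc(OC)c(OC)c(OC)c3)n2)cc1`) gives 53600 nM (a higher number than that of compound 3, by more than the scatter). Compound 3 therefore stands at the low end of this small set, level with compound 1 within the scatter.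

Compound 4 (`COc1cc(Nc2nc(Nc3ccc4c(ccn4C)c3)nnc2Cl)cc(OC)c1OC`) is reached from compound 3 by one structural change: 1-methyl-1H-indol-5-yl in place of 3-methoxyphenyl on a nitrogen on an aromatic ring. Among the compounds with values here, none of the measured compounds carries this group, and no measured step speaks to the change directly. A small move toward a lower number in this assay is therefore expected, probably not beyond the scatter. The estimated change is a 1.7-fold lower number from compound 3 to compound 4 (0.22 log units; within the scatter) and it remains uncertain. For compound 4 the expected value is 10000 nM with an estimated range of 2500 nM to 40000 nM in this assay.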

Compound 4, half-maximal inhibitory concentration: 28100 nM
Beside the measured number, compound 4's estimate is 2.8-fold (0.45 log units) below it; low and high end bracket the measured number.
By their numbers in this assay, from the lowest: compounds 3, 1, 4 and 2 (each within the scatter of the next, the first and the last beyond it).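

In this assay, placing 1-methyl-1H-indol-5-yl in place of 3-methoxyphenyl on a nitrogen on an aromatic ring gives a 1.7-fold higher number from compound 3 to compound 4 (0.23 log units; within the scatter), so this change cannot be told apart from repeat measurement. Within the data shown here, this is the first step between measured compounds that differ in one place, and it shows that a group with one five-membered and one six-membered aromatic ring can enter here without a shift beyond the scatter. Nothing measured here bears on why the step is this size.

Going by these compounds, it remains open whether a 1H-indol-5-yl group without the methyl, or a phenyl carrying an amine or a carboxylic acid, would give a step beyond the scatter at this place. Also open, on these data alone, is whether replacing the chlorine on the shared core with an amine would move the number more than this change did.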